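Swapping the Benzyl Ester for a Cyclopropylmethyl Ester

The source may hold more compounds than are shown below. What is called first, only, known or untested is meant among the compounds shown, and "the series" means these compounds.

Of the compounds shown here, three sharing one core have been measured in an assay on membranes from CHO cells for displacement of a labelled ligand from adenosine receptor A1 (Homo sapiens), read by scintillation counting, with a stated time of 60 min, tested at 1 uM; on this read-out lower numbers stand for less inhibition and higher numbers for more inhibition at the one concentration tested (going by the name of the read-out). Compound 1 `CC1=C(C(=O)OCc2ccccc2)C(c2ccoc2)NC(=O)N1` gives 41%, compound 2 `CC1=C(C(=O)OCc2ccccc2)C(c2cccs2)NC(=O)N1` gives 45%, and compound 3 `CC1=C(C(=O)OCc2ccccc2)C(c2ccsc2)NC(=O)N1` gives 57%. Compound 3 stands highest of the three: the step of a number 12 percentage points higher from compound 2 to compound 3 (beyond the scatter) and the step of a number 16 percentage points higher from compound 1 to compound 3 (beyond the scatter) both lie beyond the scatter, while the step of a number 4 percentage points higher from compound 1 to compound 2 (within the scatter) does not.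

Compound 4 `CC1=C(C(=O)OCC2CC2)C(c2ccsc2)NC(=O)N1` differs from compound 3 in one place: cyclopropyl in place of phenyl on a saturated chain carbon bound to an oxygen next to a carbonyl group. Within the data shown here, every measured step so far concerns the group on the saturated ring carbon; none touches the saturated chain carbon bound to an oxygen next to a carbonyl group, so no measured step bears on this change. With no guidance from the data, the expected step of a number 7 percentage points lower from compound 3 to compound 4 (within the scatter) is none beyond the scatter, though with a wide range. Compound 4 is therefore estimated at 50% in this assay, between 25% and 70%.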

Compound 4, a percentage reported as inhibition, at one concentration (the size of the read-out at that concentration, not a potency): 39%
Compound 4: middle estimate off by 11 percentage points, on the high side, within the range that was stated.
By their numbers in this assay, from the lowest: compounds 4, 1 and 2 (each within the scatter of the next); then compound 3.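

The earlier compounds shown here varied only the group on the saturated ring carbon. This result shows that the group on the saturated chain carbon bound to an oxygen next to a carbonyl group also counts in this assay: cyclopropyl in place of phenyl gives a number 18 percentage points lower from compound 3 to compound 4 (beyond the scatter). With thiophen-3-yl on the ring carbon, then, benzyl and cyclopropylmethyl are not interchangeable, and the more inhibition seen at the one tested concentration belongs to the benzyl ester. Nothing measured here explains why the number falls.

Among these compounds, only one pair bears on this position, so it remains open whether a similar step would appear with furan-3-yl or thiophen-2-yl on the ring carbon. The compounds shown also leave open how an ethyl ester, a longer chain or a chain carrying an amine would compare.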